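The compounds below may be only part of what the source reports. "The series", "measured", "known", "first", "only" and "open" are said of these compounds alone.

Measured compounds:
- compound 1, `COc1cc(O)c(C(=O)/C=C/c2ccc(OC)c(OC)c2)c(OC)c1`: 27600 nM
- compound 2, `COc1cc(O)c(C(=O)/C=C/c2ccc(F)cc2)c(OC)c1`: 4400 nM
- compound 3, `COc1cc(O)c(C(=O)/C=C/c2cccc(Cl)c2Cl)c(OC)c1`: 2700 nM

All three compounds share one core and were tested in a functional assay on HCT-116 cells (Homo sapiens) for antiproliferative activity, read by sulforhodamine B assay, with a stated time of 48 h; on this read-out higher numbers stand for weaker inhibition and lower numbers for stronger inhibition. Compound 1 gives 27600 nM and stands highest of the three numbers, which in this assay means the weakest inhibition. Compound 2 gives 4400 nM, a lower number beyond the scatter, and compound 3 gives 2700 nM, lower still and also beyond the scatter. No two of these compounds differ in just one place, so none of these gaps can be tied to a single structural change.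

Compound 4, `COc1cccc(/C=C/C(=O)c2c(O)cc(OC)cc2OC)c1`, has not yet been measured. It differs from compound 1 in one place: hydrogen in place of methoxy on an aromatic carbon. The place is on an aromatic carbon of a six-membered aromatic ring of carbon only, ortho to a methoxy group and para to a large group.

Since both other measured compounds, which carry fewer or different substituents on that ring, give lower numbers than compound 1, the step of a 2.8-fold lower number from compound 1 to compound 4 (0.44 log units; beyond the scatter) is expected to be a moderate drop, beyond the scatter. Compound 4 is therefore estimated at 10000 nM, within a range of 3000 nM to 30000 nM.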

Compound 4, half-maximal inhibitory concentration: 3100 nM
Estimate against measurement, compound 4: 3.2-fold (0.51 log units) above; low and high end bracket the measured number.
By their numbers in this assay, from the lowest: compounds 3, 4 and 2 (each within the scatter of the next); then compound 1.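

Read in this assay, hydrogen in place of methoxy gives an 8.9-fold lower number from compound 1 to compound 4 (0.95 log units; beyond the scatter), and this is the first gap in the set that can be tied to a single change in structure. It shows that this methoxy group, on an aromatic carbon ortho to a methoxy group and para to a large group, is not needed for the antiproliferative effect, since inhibition is stronger once the group is gone; this holds for this one pair only. Nothing at hand speaks to the reason for the drop.

The compounds shown leave open whether the gain comes from having hydrogen at this place or simply from losing methoxy, as an amine, a hydroxyl group or a longer chain such as ethoxy at the same carbon could tell these apart. Also open, going by these compounds, is what would happen if the remaining methoxy group on that ring were replaced by hydrogen too, leaving the ring with no substituent at all.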